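The compounds below may be only part of what the source reports. "The series", "measured", "known", "first", "only" and "open" are said of these compounds alone.

Measured so far:
Compound 1 `CCCCCCCCCCCCCCC/C(O)=C1/C(=O)[C@H](Cc2ccccc2)N(C(=O)OC(C)(C)C)C1=O`, which in an assay on isolated protein for inhibition of kallikrein-7 (Homo sapiens) (on this read-out higher numbers stand for weaker inhibition and lower numbers for stronger inhibition), gives 2900 nM.
Compound 2 `CCCCCCCCCCCCCCCCC/C(O)=C1/C(=O)[C@H](Cc2ccccc2)N(C(=O)OC(C)(C)C)C1=O`, which in this assay gives 2800 nM.

Compound 2 sits alongside compound 1: the step of a 1.0-fold lower number from compound 1 to compound 2 (0.02 log units; within the scatter) lies within the scatter, so the two cannot be told apart. Compound 3 `CCCCC/C=C\C/C=C\CCCCCCC/C(O)=C1/C(=O)[C@H](Cc2ccccc2)N(C(=O)OC(C)(C)C)C1=O` differs from compound 2 in that (deca-1,4-dien-1-yl in place of decyl on a saturated chain carbon, seven bonds along the chain from a double-bonded chain carbon). Among the measured compounds shown here, no measured step brings double bonds into the chain; the only measured alteration of the chain, a 1.0-fold lower number from compound 1 to compound 2 (0.02 log units; within the scatter), moved the number not at all beyond the scatter. The step of no change at the digits printed from compound 2 to compound 3 (within the scatter) is therefore expected to stay within the scatter. Compound 3 is estimated at 2800 nM, with a range from 1200 nM to 6500 nM.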

Compound 3, half-maximal inhibitory concentration: 14000 nM
For compound 3 the middle estimate is 5.0-fold (0.70 log units) below the measured one; measured number above the stated range.
By their numbers in this assay, from the lowest: compounds 2 and 1 (each within the scatter of the next); then compound 3.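

In this assay, this chain position proves sensitive to the kind of chain it carries: deca-1,4-dien-1-yl in place of decyl gives a 5.0-fold higher number from compound 2 to compound 3 (0.70 log units; beyond the scatter) and weakens inhibition, and against the octyl change the same reading is a 4.8-fold higher number from compound 1 to compound 3 (0.68 log units; beyond the scatter) on the same side. At an unchanged carbon count, two double bonds therefore move the number beyond the scatter, which the saturated extension did not do. Nothing available bears on the reason for this. Still open, on these data alone, is whether one double bond alone would do the same, and whether a longer chain or a chain carrying a carboxylic acid would restore or strengthen inhibition.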